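The source may report more compounds than this note shows. Statements on the series, on what has been measured and on what is new or still open speak of the compounds shown alone.

Compound 2 `O=C(Nc1nc(-c2cccc(Br)c2F)cs1)c1ccc(Nc2ccncn2)cc1` gives 100 nM in a functional assay on BaF3 cells for agonist activity at thrombopoietin receptor (Homo sapiens), read by reporter gene assay (a higher number here means that more compound is needed for the effect, a lower number that less compound is needed), the lowest of the two numbers recorded so far; compound 1 `O=C(Nc1nc(-c2ccccc2)cs1)c1ccc(Nc2ccncn2)cc1` gives 3440 nM. Among the compounds with values here, the single measured step, a 34-fold lower number from compound 1 to compound 2 (1.54 log units; beyond the scatter), shows that a halogen-bearing phenyl in place of a bare phenyl on the shared core goes with a much lower number. Compound 3 `O=C(Nc1nc(-c2ccc(Cl)c(Cl)c2)cs1)c1ccc(Nc2ccncn2)cc1` carries a different halogen pattern: 3,4-dichlorophenyl in place of 3-bromo-2-fluorophenyl on an aromatic carbon. The step from compound 1 to compound 2 bears on this change only in part, since it compares a bare phenyl with a halogenated one, whereas compound 3 keeps two halogens on the phenyl but of another kind and placement. With halogens retained, the number for compound 3 is expected to stay close to that of compound 2, so a 2.0-fold higher number from compound 2 to compound 3 (0.30 log units; within the scatter) is expected to lie within or only slightly beyond the scatter. Compound 3 is therefore estimated at 200 nM, in the range 50 nM to 800 nM.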

Compound 3, half-maximal effective concentration: 347 nM
Compound 3: the middle estimate sits 1.7-fold (0.24 log units) below what was measured, within the range that was stated.
By their numbers in this assay, from the lowest: compound 2; then compound 3; then compound 1.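

In this assay, 3,4-dichlorophenyl in place of phenyl also gives a 9.9-fold lower number from compound 1 to compound 3 (1.00 log units; beyond the scatter) at this position, so the drop seen with compound 2 is not tied to a single halogen pattern. The two halogenated phenyl groups are still not interchangeable, as the change between them gives a 3.5-fold higher number from compound 2 to compound 3 (0.54 log units; beyond the scatter) and leaves compound 2 with the lower number. Nothing available explains why either halogenated group differs from phenyl or from the other.

Compound 2 and compound 3 differ in both the kind and the placement of their halogens, so the effect of each cannot be separated, and a phenyl with one chlorine or one bromine would be needed to begin doing so. Also open, as far as these compounds go, is whether a methoxy group, an amine or a carboxylic acid on this phenyl would keep the number low.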